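Cytotoxicity notes: anilino swap at the shared core

This account rests on a few compounds, and the source may have more. Where it says the series, first, only, none or still open, it means among the compounds named here.

Measured so far in a functional assay on U2OS cells (Homo sapiens) for cytotoxicity, read by MTT assay, with a stated time of 48 h; a higher number here means a weaker inhibitor, a lower number a stronger inhibitor:
- compound 1 `Fc1cccc(-c2nc(Nc3ccccc3)c3cc(F)ccc3n2)c1`: 47600 nM
- compound 2 `COc1ccccc1Nc1nc(-c2cccc(F)c2)nc2ccc(F)cc12`: > 50000 nM (a limit of this assay, not a number)
- compound 3 `Fc1cccc(-c2nc(Nc3ccccc3F)c3cc(F)ccc3n2)c1`: > 50000 nM (a limit of this assay, not a number)

Compound 3 sits at the limit of this assay, so only a floor is known for it, and the step from compound 2 to compound 3 is a step that the two limits leave unreadable from compound 2 to compound 3. Among the three measured compounds, the only number is that of compound 1; the other two sit at the limit (the limit of > 50000 nM in this assay, at which 2 of the 3 values shown sit). Compound 4 `Fc1cccc(-c2nc(Nc3ccc(Br)cc3)c3cc(F)ccc3n2)c1` differs from compound 3 by 4-bromophenyl in place of 2-fluorophenyl on a nitrogen on an aromatic ring.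

For the measured compounds named here, no measured step changes the group on that nitrogen from one whole aryl to another; the two steps that touch it are an at least 1.0-fold higher number from compound 1 to compound 2 (0.02 log units; that floor lies within the scatter) and an at least 1.0-fold higher number from compound 1 to compound 3 (0.02 log units; that floor lies within the scatter), each a decoration of the phenyl rather than its exchange, and each at a floor inside the scatter. Nothing in this set moves the read-out beyond the scatter, and compound 3 itself lies at the limit, so the step of a number no higher from compound 3 to compound 4 (the limit leaves the size open) is expected to be none readable beyond the scatter, and a second limit is the likeliest outcome. For compound 4 the estimate in this assay is 50000 nM, within 25000 nM to 100000 nM.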

Compound 4, half-maximal inhibitory concentration: > 50000 nM
Compound 4 ended at the assay's limit; the forecaster's own chance of this, stated with the estimate: 65%; the middle value sits exactly at the limit.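

Compound 4 gives > 50000 nM in this assay, a limit and not a number, so this exchange of one whole aryl for another on the nitrogen, with 4-bromophenyl entering, brings no number either. Bromo in place of hydrogen on the phenyl of compound 1 gives an at least 1.0-fold higher number from compound 1 to compound 4 (0.02 log units; that floor lies within the scatter), so this decoration, like the two before it, shows no step beyond the scatter. The steps linking compound 4 to compound 2 and compound 3 cannot be read, and the limit now covers most of the series: the limit of > 50000 nM in this assay, at which 3 of the 4 values shown sit.

From the compounds shown here alone, whether any group on that nitrogen gives a value clearly lower than that of compound 1 stays open. A basic amine or a carboxylic acid on the phenyl, or a longer alkyl chain in place of the aryl, remains untested in the compounds shown here.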